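Thiosemicarbazone series: aryl swap on the imine carbon

This account rests on a few compounds, and the source may have more. Where it says the series, first, only, none or still open, it means among the compounds named here.

Measured so far:
- compound 1, `COc1ccc(/C=N/NC(=S)NC(C)(C)[C@H]2CC=C(C)CC2)cc1`: 1500 nM
- compound 2, `CC1=CC[C@H](C(C)(C)NC(=S)N/N=C/c2ccccc2Cl)CC1`: 5600 nM

Among the compounds with values here, in a functional assay on K562 cells (Homo sapiens) for inhibition, read by sulforhodamine B assay, with a stated time of 48 h (a higher number here means a weaker inhibitor of growth, a lower number a stronger inhibitor of growth), compound 2 gives 5600 nM, the higher of the two numbers known; its nearest neighbour is compound 1 with 1500 nM. Within the data shown here, the only step measured, a 3.7-fold higher number from compound 1 to compound 2 (0.57 log units; beyond the scatter), shows that a change of the aromatic group on the carbon with a double bond to nitrogen moves the number by a modest amount and beyond the scatter.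

Compound 3, `CC1=CC[C@H](C(C)(C)NC(=S)N/N=C/c2ccc[nH]2)CC1`, is not yet measured. It differs from compound 2 in one place: 1H-pyrrol-2-yl in place of 2-chlorophenyl on a carbon with a double bond to nitrogen. Among the measured compounds shown here, no measured step covers a 1H-pyrrol-2-yl group, so the direction is open. For the measured compounds named here, the single step from compound 1 to compound 2 bears on it only as a guide to size: a change at this position has so far moved this assay by a modest amount, and a step of similar size in either direction is the expectation here.

For compound 3 the expected value in this assay is 4000 nM, with a range of 1200 nM to 13000 nM, corresponding to an estimated step of a 1.4-fold lower number from compound 2 to compound 3 (0.15 log units; within the scatter).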

Compound 3, concentration for 50% growth inhibition: 23400 nM
Compound 3: middle estimate off by 5.9-fold (0.77 log units), on the low side; measured number above the stated range.
By their numbers in this assay, from the lowest: compound 1; then compound 2; then compound 3.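

In this assay, within the data shown here, this position proves more sensitive than the first pair suggested: the widest gap among the three compounds is a 16-fold higher number from compound 1 to compound 3 (1.19 log units; beyond the scatter) and is large, whereas the only earlier step was modest. Among these compounds, the 1H-pyrrol-2-yl group also gives the first evidence that a substituted phenyl ring need not be interchangeable with a smaller aromatic ring here, since a 4.2-fold higher number from compound 2 to compound 3 (0.62 log units; beyond the scatter) and compound 3 is now the weakest of the three inhibitors of growth. This change replaces a six-membered carbon ring with a five-membered ring with 1 hetero atom and adds a hydrogen-bond donor, and the data offer no explanation for the loss, nor does any supporting measurement bear on it.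

These compounds cannot separate the effect of ring size from that of the ring's nitrogen and its hydrogen, a question that furan-2-yl, thiophen-2-yl and 1-methyl-1H-pyrrol-2-yl groups would address. Also open, going by these compounds, is how an unsubstituted phenyl group or a pyridin-2-yl group would rank against compound 1 and compound 2 on the same core.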